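A few compounds are considered here, and "the series" means these few. Any claim that something is new, unique, unknown or untested is made for them only; others in the source may bear on it.

Measured in an ADME assay on a cell-free system (plasma, Homo sapiens) for metabolic stability, read by LC-MS (on this read-out higher numbers stand for a longer-lived compound and lower numbers for a shorter-lived compound), all three values are limits:
- compound 1 `CCCOC(=O)c1ccc(NC(=O)c2cccc(-c3cc(C(=O)Nc4ccncc4F)ccc3CN)c2)cc1` gives > 2 h
- compound 2 `NCc1ccc(C(=O)Nc2ccncc2F)cc1-c1cccc(C(=O)Nc2ccc(CC(=O)O)cc2)c1` gives > 2 h
- compound 3 `NCc1ccc(C(=O)Nc2ccncc2F)cc1-c1cccc(C(=O)Nc2ccccc2)c1` gives > 2 h

Compound 3 stands at > 2 h, which is a limit and not a number. For the measured compounds named here, the other two compounds give no number either, so the series so far rests on (the limit of > 2 h in this assay, at which 3 of the 3 values shown sit).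

Compound 4 `NCc1ccc(C(=O)Nc2ccncc2F)cc1-c1cccc(C(=O)Nc2cccc(C(=O)O)c2F)c1` carries 3-carboxy-2-fluorophenyl in place of phenyl on an amide-type nitrogen.

The measured steps that bear on this change are a step that the two limits leave unreadable from compound 1 to compound 3 and a step that the two limits leave unreadable from compound 2 to compound 3. Both replace a substituted ring with the phenyl of compound 3, and neither has a readable size. The same holds for a step that the two limits leave unreadable from compound 1 to compound 2. No measured change to this ring has taken a compound off the limit, so no step beyond the scatter is expected in this assay, and no direction can be given. The expected step is a step that the limit leaves unreadable from compound 3 to compound 4. Compound 4 will most likely be reported as a limit as well. For compound 4 the estimated half-life is 3 h, with an expected range from 2 h to 8 h.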

Compound 4, half-life: > 2 h
Compound 4: only a limit was reported; the forecaster's own chance of this, stated with the estimate: 85%; the middle value lies beyond the limit too.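

Compound 4 gives > 2 h, a limit and not a number, so its steps from compound 1, compound 2 and compound 3 cannot be read: the limit of > 2 h in this assay, at which 4 of the 4 values shown sit.

As far as these compounds go, the actual half-lives of all four compounds remain open, and with them whether the groups on the amide-type nitrogen differ at all.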